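From an Ethylphenyl to an Indanyl Ring Substituent

The source may report more compounds than this note shows. Statements on the series, on what has been measured and on what is new or still open speak of the compounds shown alone.

In an assay for inhibition of NADPH oxidase 1 (Homo sapiens), read by chemiluminescence (on this read-out lower numbers stand for stronger inhibition and higher numbers for weaker inhibition), compound 2 `CCc1ccc(N2C(=O)/C(=C/c3ccc(N(C)C)cc3)N(C)C2=S)cc1` gives 4390 nM, the lowest of the two numbers measured, while compound 1 `CN1C(=S)N(C2CCCCC2)C(=O)/C1=C/c1ccc(O)cc1O` gives 26000 nM. Compound 3 `CN1C(=S)N(c2ccc3c(c2)CCC3)C(=O)/C1=C/c1ccc(N(C)C)cc1` has not been measured. It differs from compound 2 by 2,3-dihydro-1H-inden-5-yl in place of 4-ethylphenyl on an amide-type nitrogen in a ring. For the measured compounds named here, no measured pair shows such a step, so no change beyond the scatter is expected in this assay in either direction. The expected step of a 1.1-fold lower number from compound 2 to compound 3 (0.04 log units; within the scatter) is small. Compound 3 is estimated at 4000 nM, with a range from 1500 nM to 12000 nM.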

Compound 3, inhibition constant: 8040 nM
For compound 3 the middle estimate is 2.0-fold (0.30 log units) below the measured one; the range from low to high includes it.
By their numbers in this assay, from the lowest: compounds 2 and 3 (each within the scatter of the next); then compound 1.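

On the amide-type nitrogen in a ring, 2,3-dihydro-1H-inden-5-yl in place of 4-ethylphenyl gives a 1.8-fold higher number from compound 2 to compound 3 (0.26 log units; within the scatter) in this assay. This first single-place step shows that the two groups cannot be told apart in this assay, so the added five-membered non-aromatic ring of carbon brings no change beyond the scatter. Going by these compounds, whether a longer chain in place of the ethyl, or an amine or a carboxylic acid on the aromatic ring, would move the number stays open. No measurement shown here speaks to the reason for this result.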